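Amide series: replacing the pyrrolidine with a primary amine

The source may report more compounds than this note shows. Statements on the series, on what has been measured and on what is new or still open speak of the compounds shown alone.

Three members of the series have been measured in a functional assay on HEK293 cells for activation of melanin-concentrating hormone receptor 1 (Rattus norvegicus), read by inositol phosphate accumulation; a higher number here means that more compound is needed for the effect, a lower number that less compound is needed. Compound 1 `O=C(CCc1ccc(C(F)(F)F)cc1)Nc1ccc2nc(N3CCC(NS(=O)(=O)O)C3)ccc2c1` gives 50 nM; compound 2 `CN(c1ccc2cc(NC(=O)CCc3ccc(C(F)(F)F)cc3)ccc2n1)C1CCCCC1` gives 1200 nM; compound 3 `CC1CCN(c2ccc3cc(NC(=O)CCc4ccc(C(F)(F)F)cc4)ccc3n2)C1` gives 400 nM. Compound 3 thus holds the second highest of the three numbers, with compound 2 nearest and compound 1 furthest.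

Compound 4 `Nc1ccc2cc(NC(=O)CCc3ccc(C(F)(F)F)cc3)ccc2n1` differs from compound 3 by amino in place of 3-methylpyrrolidin-1-yl on an aromatic carbon, on the aromatic carbon next to the ring nitrogen of the shared core.

Within the data shown here, two measured steps touch the same position. Going a 24-fold higher number from compound 1 to compound 2 (1.38 log units; beyond the scatter), and going a 3.0-fold lower number from compound 2 to compound 3 (0.48 log units; beyond the scatter). The direct comparison an 8.0-fold higher number from compound 1 to compound 3 (0.90 log units; beyond the scatter) shows the same ordering. All three changes at this carbon moved the number beyond the scatter, so the position is sensitive, but none of them removes the saturated ring altogether, and nothing here tells whether a bare amino group behaves like the 3-methylpyrrolidin-1-yl of compound 3 or worse.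

Given that uncertainty, the step of a 1.8-fold higher number from compound 3 to compound 4 (0.24 log units; within the scatter) is expected to be modest and toward a higher number. Compound 4 is estimated at 700 nM, within a range from 150 nM to 3000 nM.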

Compound 4, half-maximal effective concentration: 720 nM
Beside the measured number, compound 4's estimate is 1.0-fold (0.01 log units) below it, and the stated range covers the measured number.
By their numbers in this assay, from the lowest: compound 1; then compounds 3, 4 and 2 (each within the scatter of the next, the first and the last beyond it).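

Removing the saturated ring altogether costs little on this aromatic carbon: in this assay the amino group of compound 4 stays within the scatter of the 3-methylpyrrolidin-1-yl of compound 3 (a 1.8-fold higher number from compound 3 to compound 4 (0.26 log units; within the scatter)) and of the cyclohexyl(methyl)amino of compound 2 (a 1.7-fold lower number from compound 2 to compound 4 (0.22 log units; within the scatter)), even though compounds 2 and 3 lie beyond the scatter of each other. Among the groups at this position, only the 3-(sulfoamino)pyrrolidin-1-yl of compound 1 stands clearly apart from the amino group (a 14-fold higher number from compound 1 to compound 4 (1.16 log units; beyond the scatter)), so a ring at this carbon is not by itself what separates compound 1 from the rest. No supporting evidence bears on why these numbers fall as they do.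

The compounds shown leave open whether the low number of compound 1 depends on the sulfoamino group itself or on its placement on the pyrrolidine ring, a question that a pyrrolidine carrying a primary amine or a carboxylic acid in that place would address. Also open, on these data alone, is whether a sulfoamino group attached directly to this aromatic carbon, without the ring, would stand apart from the amino group in the same way.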